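Swapping the Aryl Thioether in a Benzamide Series

The source may report more compounds than this note shows. Statements on the series, on what has been measured and on what is new or still open speak of the compounds shown alone.

In a functional assay on HCT-116 cells (Homo sapiens) for antiproliferative activity, read by CCK-8 assay, with a stated time of 72 h (on this read-out lower numbers stand for stronger inhibition and higher numbers for weaker inhibition), compound 2 `Nc1ccccc1NC(=O)c1ccc(CSc2cccc(F)c2)cc1` gives 2870 nM and stands with the higher of the two numbers recorded; its nearest neighbour, compound 1 `Nc1ccccc1NC(=O)c1ccc(CSc2nccc(C(F)(F)F)n2)cc1`, gives 1140 nM, a gap that lies beyond the usual scatter. Compound 3 `CC(C)(C)c1ccc(SCc2ccc(/C=C/C(=O)Nc3ccccc3N)cc2)cc1` is recorded in this assay as "not determined" (no result reported), so it offers nothing to compare. Compound 4 `CCc1ccc(SCc2ccc(C(=O)Nc3ccccc3N)cc2)cc1` has not yet been measured. It differs from compound 2 in one place: 4-ethylphenyl in place of 3-fluorophenyl on a sulfur. Within the data shown here, no measured pair shares this exact change, so the size of the step has to be judged without precedent. Given that the remaining data do not show how an alkyl group on this ring behaves, the expected step in this assay is small and stays within the scatter, with a slight lean towards a lower number: a 1.4-fold lower number from compound 2 to compound 4 (0.16 log units; within the scatter). Compound 4 is therefore estimated to give 2000 nM in this assay, within a range of 700 nM to 6000 nM.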

Compound 4, half-maximal inhibitory concentration: 1740 nM
Estimate against measurement, compound 4: 1.1-fold (0.06 log units) above; the range from low to high includes it.
By their numbers in this assay, from the lowest: compounds 1, 4 and 2 (each within the scatter of the next, the first and the last beyond it).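

In this assay, among these compounds, the change gives a 1.6-fold lower number from compound 2 to compound 4 (0.22 log units; within the scatter) and so gives the first reading of an alkyl-bearing ring at this position. On a sulfur whose other neighbour is a saturated chain carbon, 4-ethylphenyl and 3-fluorophenyl cannot be told apart in this assay, so replacing the fluorine with an ethyl group, and moving to a different substitution pattern, leaves no change beyond the scatter. Nothing in the information available accounts for this result.

The compounds shown leave open how an unsubstituted phenyl, a longer chain such as butyl, or an amine on this ring would read. Compound 3, with its tert-butyl group, has no result and also differs elsewhere in its structure, so it provides no second alkyl reading.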